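Dichlorophenyl for acetamidophenyl on a sulfonyl hydrazide

This account rests on a few compounds, and the source may have more. Where it says the series, first, only, none or still open, it means among the compounds named here.

Compound 1, `CC(=O)Nc1ccc(S(=O)(=O)NNC(=O)c2cccnc2Nc2ccc(Cl)cc2)cc1`: > 100000 nM
Compound 2, `O=C(NNS(=O)(=O)c1ccc(F)cc1)c1cccnc1Nc1ccc(Cl)cc1Cl`: 97700 nM

In a functional assay on NCI-H226 cells (Homo sapiens) for antiproliferative activity (on this read-out higher numbers stand for weaker inhibition of growth and lower numbers for stronger inhibition of growth), compound 1 gives > 100000 nM, and this is a limit of the assay rather than a number. Where compound 1 stands is shown by the limit of > 100000 nM in this assay, at which 1 of the 2 values shown sits. In this assay compound 2 gives 97700 nM. Going by the values given here, no step between two measured compounds is available here. Compound 3, `O=C(NNS(=O)(=O)c1ccc(Cl)cc1Cl)c1cccnc1Nc1ccc(Cl)cc1`, differs from compound 1 by 2,4-dichlorophenyl in place of 4-acetamidophenyl on a sulfonyl sulfur. Without a measured step to lean on, the change in this assay is expected to stay within the scatter, with no clear direction. Compound 3 is expected to give 90000 nM in this assay, within a range from 25000 nM to 200000 nM. The expected step is an at least 1.1-fold lower number from compound 1 to compound 3 (0.04 log units; that floor lies within the scatter).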

Compound 3, concentration for total growth inhibition: 58900 nM
Beside the measured number, compound 3's estimate is 1.5-fold (0.18 log units) above it; the measured number falls inside the stated range.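

In this assay, putting 2,4-dichlorophenyl on the sulfonyl sulfur in place of 4-acetamidophenyl gives an at least 1.6-fold lower number from compound 1 to compound 3 (0.22 log units; that floor lies within the scatter). Compound 1 has only a limit, so this step is a floor and its true size cannot be read: the limit of > 100000 nM in this assay, at which 1 of the 3 values shown sits. At this place, then, a group with no hydrogen-bond donor or acceptor replaces one that has both without any sign of weaker growth inhibition.

From the compounds shown here alone, whether an aminophenyl or a carboxyphenyl group on this sulfur would inhibit growth more strongly remains open. So does whether a single chlorine would serve as well as two.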